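A Methyl Step Repeated on a Simpler Core

This account rests on a few compounds, and the source may have more. Where it says the series, first, only, none or still open, it means among the compounds named here.

Measured compounds: compound 1 `O=C(COc1ccc(Cl)cc1)Nc1nc(-c2ccc(Br)cc2)cs1` gives 52100 nM in a functional assay on MDA-MB-468 cells (Homo sapiens) for cytotoxicity, read by MTT assay, with a stated time of 48 h; a higher number here means a weaker inhibitor, a lower number a stronger inhibitor; compound 2 `Cc1cc(OCC(=O)Nc2nc(-c3ccc(Br)cc3)cs2)ccc1Cl` gives 52100 nM in this assay; compound 3 `O=C(COc1ccccc1)Nc1nc(-c2ccc(Br)cc2)cs1` gives 37200 nM in this assay.

The change from compound 1 to compound 2 is methyl in place of hydrogen on an aromatic carbon, and its step was no change at the digits printed from compound 1 to compound 2 (within the scatter). Compound 4 `Cc1ccccc1OCC(=O)Nc1nc(-c2ccc(Br)cc2)cs1` carries the same kind of change relative to compound 3, (methyl in place of hydrogen on an aromatic carbon). The two places are not identical: in compound 4 the methyl sits ortho to a large group, whereas in compound 2 it sits ortho to a chloro group and meta to a large group. The two cores differ by hydrogen in place of chloro on an aromatic carbon, a step of a 1.4-fold lower number from compound 1 to compound 3 (0.15 log units; within the scatter). The earlier methyl step of no change at the digits printed from compound 1 to compound 2 (within the scatter) is the basis for the expectation here. Compound 4 is therefore expected to give about 38000 nM, most likely between 15000 nM and 95000 nM. The expected step is a 1.0-fold higher number from compound 3 to compound 4 (0.01 log units; within the scatter).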

Compound 4, half-maximal inhibitory concentration: 44900 nM
Compound 4: middle estimate off by 1.2-fold (0.07 log units), on the low side, and the stated range covers the measured number.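

In this assay, the methyl change on the simpler core gives a 1.2-fold higher number from compound 3 to compound 4 (0.08 log units; within the scatter), and the two other comparisons give a 1.2-fold lower number from compound 2 to compound 4 (0.06 log units; within the scatter) and a 1.2-fold lower number from compound 1 to compound 4 (0.06 log units; within the scatter). Set beside the earlier methyl step, the new one shows that the change behaves alike on both cores: the same change on two cores in this assay, no change at the digits printed (within the scatter) from compound 1 to compound 2 and a 1.2-fold higher number (0.08 log units; within the scatter) from compound 3 to compound 4, 1.2-fold (0.08 log units) apart, within the scatter of two such steps This agreement is only between two steps that are each too small to read, and the methyl sits in a different place on each core, so it does not show that a methyl step with a real effect would carry over from one core to another.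

As far as these compounds go, whether an amine or a carboxylic acid on the phenoxy ring would move the number beyond the scatter stays open. So does how a methyl would behave on any other core.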